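The compounds below may be only part of what the source reports. "The series", "measured", "known", "first", "only" and "open" are said of these compounds alone.

The measured compounds:

compound 1 `O=C(CN1CCN(C2CCCCC2)CC1)Nc1nc2c(s1)CCCC2`: > 1000 nM
compound 2 `O=C(CN1CCN(c2cccc(F)c2)CC1)Nc1nc2c(s1)CCCC2`: > 1000 nM
compound 3 `Cc1ccc(N2CCN(CC(=O)Nc3nc4c(s3)CCCC4)CC2)cc1`: 250 nM

Going by the values given here, in an assay on isolated protein for inhibition of long-chain fatty acid transport protein 1 (Homo sapiens), read by scintillation counting, with a stated time of 20 min (on this read-out higher numbers stand for weaker inhibition and lower numbers for stronger inhibition), compound 3 holds the only value that is a number. The value of compound 1 is a limit of the assay. The value of compound 2 is likewise a limit (the limit of > 1000 nM in this assay, at which 2 of the 3 values shown sit). Compound 4 `O=C(CN1CCN(c2ccccn2)CC1)Nc1nc2c(s1)CCCC2` differs from compound 3 in one place: pyridin-2-yl in place of 4-methylphenyl on an amine nitrogen in a ring. Among the compounds with values here, two measured steps bear on this change, an at least 4.0-fold lower number from compound 1 to compound 3 (0.60 log units; beyond the scatter) and an at least 4.0-fold lower number from compound 2 to compound 3 (0.60 log units; beyond the scatter); both run towards compound 3 and mark the 4-methylphenyl group as the one giving the lowest number. Replacing it with pyridin-2-yl, an aromatic group without the methyl, is expected to move the number back towards the limit, so a step of a 4.0-fold higher number from compound 3 to compound 4 (0.60 log units; beyond the scatter) is estimated. Compound 4 is therefore expected at 1000 nM, within 300 nM to 3000 nM.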

Compound 4, half-maximal inhibitory concentration: 200 nM
The estimate for compound 4 lay 5.0-fold (0.70 log units) above the measured number, and the stated range ends above it.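

In this assay, 4-methylphenyl and pyridin-2-yl on the amine nitrogen in a ring cannot be told apart, with a 1.3-fold lower number from compound 3 to compound 4 (0.10 log units; within the scatter). Pyridin-2-yl is also clearly separated from the other two groups, with an at least 5.0-fold lower number from compound 2 to compound 4 (0.69 log units; beyond the scatter) and an at least 5.0-fold lower number from compound 1 to compound 4 (0.69 log units; beyond the scatter), yet compound 2 also carries an aromatic ring, so such a ring alone does not decide the outcome. Both of these steps are open-ended, since compound 1 and compound 2 sit at a limit: the limit of > 1000 nM in this assay, at which 2 of the 4 values shown sit.

As far as these compounds go, what stays open is how phenyl, 4-fluorophenyl or pyridin-4-yl would compare on this amine nitrogen. From the compounds shown here alone, it also stays open whether the fluorine of compound 2 or its place on the ring sets that compound apart.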